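Notes on the amine change from compound 2 to compound 4

The source may hold more compounds than are shown below. What is called first, only, known or untested is meant among the compounds shown, and "the series" means these compounds.

Measured compounds:
compound 1 `COc1cc(C)c(S(=O)(=O)N(C)CCOCC(=O)N2CCC(N3CCN(C(C)C)CC3)CC2)c(C)c1`: 3.8 nM
compound 2 `CCN(CC)CCN1CCN(C(=O)COCCN(C)S(=O)(=O)c2c(C)cc(OC)cc2C)CC1`: 10 nM
compound 3 `COc1ccc(S(=O)(=O)N(C)CCOCC(=O)N(C)Cc2ccc(C3=NCCN3)cc2)c(C)c1`: 5.5 nM

In an assay on HEK293 cells for displacement of a labelled ligand from B1 bradykinin receptor (Homo sapiens), read by scintillation counting (a higher number here means a weaker inhibitor, a lower number a stronger inhibitor), compound 2 gives 10 nM, the highest of the three numbers. Compound 3 gives 5.5 nM, which lies within the scatter of compound 2, whereas compound 1 gives 3.8 nM, a lower number beyond the scatter. Compound 4 `COc1cc(C)c(S(=O)(=O)N(C)CCOCC(=O)N2CCN(CCN(C)C)CC2)c(C)c1` has not been measured. It differs from compound 2 in one place: dimethylamino in place of diethylamino on a saturated chain carbon, two bonds along the chain from an amine nitrogen in a ring. For the measured compounds named here, no pair of measured compounds isolates this change, so its size is open. Since the change is small in count, the expected step from compound 2 to compound 4 is a 1.3-fold lower number from compound 2 to compound 4 (0.10 log units; within the scatter), not beyond the scatter. Compound 4 is expected to give 8 nM, between 3 nM and 20 nM.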

Compound 4, inhibition constant: 106 nM
Compound 4: the middle estimate sits 13-fold (1.12 log units) below what was measured; measured number outside the range, above it.
By their numbers in this assay, from the lowest: compounds 1, 3 and 2 (each within the scatter of the next, the first and the last beyond it); then compound 4.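

In this assay, this position proves sensitive to a small change: dimethylamino in place of diethylamino on the chain gives an 11-fold higher number from compound 2 to compound 4 (1.03 log units; beyond the scatter), a large step for a change from 5 heavy atoms to 3. The earlier compounds shown here, with no step between them, gave no measure of how much this amine matters. No evidence at hand bears on the origin of this step.

The compounds shown leave open how ethylmethylamino or diisopropylamino would read at this position. Also open, as far as these compounds go, is whether the same change gives a step of this size on another core.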